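The source may report more compounds than this note shows. Statements on the series, on what has been measured and on what is new or still open speak of the compounds shown alone.

Measured so far in a functional assay on MCF7 cells (Homo sapiens) for cytotoxicity, read by MTT assay, with a stated time of 48 h; on this read-out lower numbers stand for stronger inhibition and higher numbers for weaker inhibition:
compound 1, `C/C(=N\NC(=S)Nc1ccccc1I)c1ccccn1`, compound 1 gives 4.1 nM
compound 2, `C/C(=N\NC(=S)Nc1ccccc1Cl)c1ccccn1`, compound 2 gives 0.16 nM
compound 3, `CC(=NNC(=S)Nc1ccc(I)cc1)c1ccccn1`, compound 3 gives 6.6 nM

The change from compound 1 to compound 2 is chloro in place of iodo on an aromatic carbon; it brings a 26-fold lower number from compound 1 to compound 2 (1.41 log units; beyond the scatter). How the core of compound 3 differs from that of compound 1 is not broken down here; compound 3 and compound 1 give numbers within the scatter of each other.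

Compound 4, `CC(=NNC(=S)Nc1ccc(Cl)cc1)c1ccccn1`, is not yet measured. It differs from compound 3 by chloro in place of iodo on an aromatic carbon. This is the same kind of change as that from compound 1 to compound 2, but the place differs: ortho to a large group in the earlier pair, para to a large group here. The step expected in this assay is a 13-fold lower number from compound 3 to compound 4 (1.12 log units; beyond the scatter). Among the compounds with values here, that expectation rests on the single earlier step, a 26-fold lower number from compound 1 to compound 2 (1.41 log units; beyond the scatter). Within the data shown here, only one such precedent exists, so the expected step is kept more moderate. Compound 4 is therefore estimated at 0.5 nM, with a range from 0.1 nM to 3 nM.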

Compound 4, half-maximal inhibitory concentration: 8.5 nM
Beside the measured number, compound 4's estimate is 17-fold (1.23 log units) below it; measured number above the stated range.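

In this assay, chloro in place of iodo on an aromatic carbon, para to a large group, brings a 1.3-fold higher number from compound 3 to compound 4 (0.11 log units; within the scatter). The size of this change therefore does not carry over from one core to the other: the same change on two cores in this assay, a 26-fold lower number (1.41 log units; beyond the scatter) from compound 1 to compound 2 and a 1.3-fold higher number (0.11 log units; within the scatter) from compound 3 to compound 4, 33-fold (1.52 log units) apart, beyond the scatter of two such steps. Within the data shown here, with a single pair on each core, this shows only that the earlier step cannot be assumed to apply elsewhere; it does not show which difference between the two cores sets the size of the step, nor give a rule for other cores.

The halogens shown are only iodo and chloro. On these data alone, how bromo, fluoro, methoxy or an amine would behave in the same place on either core remains open.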